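A Hexylamide Series and an Unmeasured Acid

A few compounds are considered here, and "the series" means these few. Any claim that something is new, unique, unknown or untested is made for them only; others in the source may bear on it.

Of the compounds shown here, three built on a shared core have been measured in a functional assay on HCT-116 cells (Homo sapiens) for antiproliferative activity; a lower number here means a stronger inhibitor of growth, a higher number a weaker inhibitor of growth. Compound 1 `CCCCCCNC(=O)c1cc(/C=C\c2cc(OC)ccc2OC)ccc1OC` gives 21100 nM in this assay. Compound 2 `CCCCCCNC(=O)c1cc(C#Cc2cc(OC)ccc2OC)ccc1OC` gives 6900 nM in this assay. Compound 3 `CCCCCCNC(=O)c1cc(CCc2cc(O)ccc2O)ccc1O` gives 3600 nM in this assay. Among these three numbers compound 2 holds the second highest; its nearest neighbour is compound 3, whose number lies within the scatter of compound 2, so no order between them can be read, while compound 1 sits furthest away, beyond the scatter, with the higher number of the two.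

Compound 4 `COc1ccc(OC)c(C#Cc2ccc(OC)c(C(=O)O)c2)c1` has not yet been measured. Relative to compound 2 the change is hydroxy in place of hexylamino on a carbonyl carbon. For the measured compounds named here, no measured pair in this set shows a step of this kind, so the expectation rests on the change itself. A step toward a higher number in this assay is expected, of a size a 4.3-fold higher number from compound 2 to compound 4 (0.64 log units; beyond the scatter), beyond the scatter. For compound 4 the expected value in this assay is 30000 nM, with a range from 8000 nM to 100000 nM.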

Compound 4, concentration for 50% growth inhibition: 32300 nM
The estimate for compound 4 lay 1.1-fold (0.03 log units) below the measured number, within the range that was stated.
By their numbers in this assay, from the lowest: compounds 3 and 2 (each within the scatter of the next); then compounds 1 and 4 (each within the scatter of the next).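

For the compounds shown here, this pair is the first to differ in one place only, so the group on the carbonyl carbon can now be judged by itself: in this assay, hydroxy in place of hexylamino gives a 4.7-fold higher number from compound 2 to compound 4 (0.67 log units; beyond the scatter) with the rest of the structure unchanged. The two groups are therefore not interchangeable at this place, and of these two compounds, the one carrying hexylcarbamoyl is the stronger inhibitor of growth. No measurement here explains why the number rises.

The compounds shown leave open how much of the hexyl chain matters, since a shorter butylamino group or a plain amino group on the same carbonyl carbon could fall anywhere along this step. On these data alone, it is also open whether a methyl ester there would lie closer to compound 2 or to compound 4.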